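Trifluoromethyl on the benzyl ring of a sulfonylguanidine

The source may hold more compounds than are shown below. What is called first, only, known or untested is meant among the compounds shown, and "the series" means these compounds.

Measured so far:
compound 1 `Cc1cc(-c2ccccc2)n(/C(N)=N/S(=O)(=O)c2cc(C)c(Cl)cc2SCc2cccc3ccccc23)n1`, 3000 nM;
compound 2 `Cc1cc(-c2ccccc2)n(/C(N)=N/S(=O)(=O)c2cc(C)c(Cl)cc2SCc2cccc(C(F)(F)F)c2)n1`, 98000 nM;
compound 3 `Cc1cc(S(=O)(=O)/N=C(\N)n2nccc2-c2ccccc2)c(SCc2ccccc2)cc1Cl`, 5000 nM.

In a functional assay on HeLa cells (Homo sapiens) for cytotoxicity, read by MTT assay, with a stated time of 72 h (a lower number here means a stronger inhibitor, a higher number a weaker inhibitor), compound 3 gives 5000 nM, the second highest of the three numbers. Compound 1 gives 3000 nM, which lies within the scatter of compound 3, so no order can be read between them. Compound 2 gives 98000 nM, beyond the scatter and the highest number here.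

Compound 4 `Cc1cc(S(=O)(=O)/N=C(\N)n2nccc2-c2ccccc2)c(SCc2ccc(C(F)(F)F)cc2)cc1Cl` differs from compound 3 by trifluoromethyl in place of hydrogen on an aromatic carbon. For the measured compounds named here, no measured step matches this change exactly, but one bears on it: a 33-fold higher number from compound 1 to compound 2 (1.51 log units; beyond the scatter), where a trifluoromethyl-bearing phenyl entered on the same chain carbon and the number rose sharply. The entering group in compound 4 is the same substituent on a different ring position, and the comparison with compound 3 is clean, so a weaker compound is expected, though less far than that step went. The estimate for compound 4 is therefore a step of a 5.0-fold higher number from compound 3 to compound 4 (0.70 log units; beyond the scatter), giving an expected 25000 nM with a range from 6000 nM to 100000 nM.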

Compound 4, half-maximal inhibitory concentration: 17000 nM
Estimate against measurement, compound 4: 1.5-fold (0.17 log units) above; the measured number falls inside the stated range.
By their numbers in this assay, from the lowest: compounds 1 and 3 (each within the scatter of the next); then compound 4; then compound 2.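

In this assay the step of a 3.4-fold higher number from compound 3 to compound 4 (0.53 log units; beyond the scatter) isolates trifluoromethyl in place of hydrogen on an aromatic carbon, para to a large group, with the rest of the molecule unchanged. The earlier step of a 33-fold higher number from compound 1 to compound 2 (1.51 log units; beyond the scatter) exchanged naphthalen-1-yl for 3-(trifluoromethyl)phenyl, so it could not show what trifluoromethyl does by itself; here the group alone gives a modest rise beyond the scatter, a weakening on this ring. No available evidence bears on what lies behind this rise.

Going by these compounds, whether the rise is specific to trifluoromethyl remains open, since a methoxy group, an amine or a carboxylic acid in the same place might move the number differently. On these data alone, it is also open whether the step would keep its size with trifluoromethyl elsewhere on this ring.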